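Swapping the aryl group on the piperazine of an oxindole thiosemicarbazone

The source may report more compounds than this note shows. Statements on the series, on what has been measured and on what is new or still open speak of the compounds shown alone.

Measured compounds:
- compound 1 `O=C1Nc2cccc(Br)c2/C1=N/NC(=S)N1CCN(c2ccccc2)CC1`: 33600 nM
- compound 2 `O=C1Nc2cccc(Cl)c2/C1=N/NC(=S)N1CCN(c2ccccc2)CC1`: 42100 nM
- compound 3 `Cc1ccc(N2CCN(C(=S)N/N=C3\C(=O)Nc4ccc(Cl)cc43)CC2)cc1`: 6390 nM

In a functional assay on HCT-116 cells (Homo sapiens) for inhibition, read by MTT assay, with a stated time of 72 h (a higher number here means a weaker inhibitor, a lower number a stronger inhibitor), compound 3 gives the lowest number of the three, and its distance from compound 1 and from compound 2 is beyond the usual scatter, so it is the strongest inhibitor in this set. Within the data shown here, the only single-point comparison among the measured compounds is a 1.3-fold higher number from compound 1 to compound 2 (0.10 log units; within the scatter), a change on the aromatic carbon of the shared core that does not touch the piperazine end of the molecule.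

Compound 4 `O=C1Nc2ccc(Cl)cc2/C1=N/NC(=S)N1CCN(c2ccccc2Cl)CC1` differs from compound 3 at that other end: 2-chlorophenyl in place of 4-methylphenyl on an amine nitrogen in a ring. Among the measured compounds shown here, no measured pair shows what exchanging the group on the amine nitrogen in the ring does, so there is no direct basis for expecting a step in either direction beyond the scatter in this assay. The nearest guide is the number of compound 3 itself, with the wider spread of compound 1 and compound 2 marking how far a change elsewhere can reach. The expectation is therefore a 1.6-fold higher number from compound 3 to compound 4 (0.19 log units; within the scatter), a small step. On that basis compound 4 is estimated at 10000 nM, with a range from 3000 nM to 35000 nM.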

Compound 4, half-maximal inhibitory concentration: 4910 nM
Estimate against measurement, compound 4: 2.0-fold (0.31 log units) above; low and high end bracket the measured number.
By their numbers in this assay, from the lowest: compounds 4 and 3 (each within the scatter of the next); then compounds 1 and 2 (each within the scatter of the next).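

In this assay, among these compounds, exchanging the group on the amine nitrogen in the ring gives a 1.3-fold lower number from compound 3 to compound 4 (0.11 log units; within the scatter), the first reading of a change at this end of the molecule. With the shared core held constant, 2-chlorophenyl and 4-methylphenyl cannot be told apart in this assay, so this position tolerates either group, and a chlorine can take the place of the methyl carbon without a step beyond the scatter. Nothing at hand explains this result.

As far as these compounds go, compound 1 and compound 2 carry a plain phenyl group on a differently substituted core, so what the chlorine or methyl adds to a plain phenyl group remains open. Also open, from the compounds shown here alone, is what an amine or a carboxylic acid on this aromatic ring would do, or a longer chain in place of the ring.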